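Methoxy for hydroxy on the chalcone aryl ketone

The source may report more compounds than this note shows. Statements on the series, on what has been measured and on what is new or still open speak of the compounds shown alone.

Measured so far:
compound 1 `COc1cc(OC)c(OC)cc1/C=C/C(=O)c1ccc(O)cc1` — 182000 nM
compound 2 `COc1cc(OC)c(C(=O)/C=C/c2cc(OC)c(OC)cc2OC)c(OC)c1` — 51400 nM

In a functional assay on MCF7 cells (Homo sapiens) for inhibition, read by MTT assay, with a stated time of 72 h (on this read-out higher numbers stand for weaker inhibition and lower numbers for stronger inhibition), compound 1 gives the highest number of the two; compound 2 gives a lower number, beyond the scatter. Among the compounds with values here, no single-point step between measured compounds exists, so nothing direct anchors the change. Compound 3 `COc1ccc(C(=O)/C=C/c2cc(OC)c(OC)cc2OC)cc1` differs from compound 1 by methyl in place of hydrogen on an oxygen on an aromatic ring. Within the data shown here, the only guide is compound 2, whose value 51400 nM pairs a fully methoxylated pattern with a lower number. A modest step toward stronger inhibition, possibly within the scatter, is expected: a 1.8-fold lower number from compound 1 to compound 3 (0.26 log units; within the scatter). Compound 3 is therefore estimated at 100000 nM, with a range from 40000 nM to 250000 nM.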

Compound 3, half-maximal inhibitory concentration: 33900 nM
Beside the measured number, compound 3's estimate is 2.9-fold (0.47 log units) above it, and the stated range ends above it.
By their numbers in this assay, from the lowest: compounds 3 and 2 (each within the scatter of the next); then compound 1.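

In this assay, hydroxy to methoxy at this position gives the series its first direct step, a 5.4-fold lower number from compound 1 to compound 3 (0.73 log units; beyond the scatter) and beyond the scatter. A single change, methyl in place of hydrogen on an oxygen on an aromatic ring, is therefore enough to lower the number on the shared core. Going by these compounds, whether a longer chain such as ethyl on the same oxygen would lower it further remains open, as does the outcome with an amine in place of the hydroxy. Nothing on hand explains the step.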